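The source may hold more compounds than are shown below. What is called first, only, known or untested is meant among the compounds shown, and "the series" means these compounds.

Measured compounds:
- compound 1 `NC(=S)N/N=C1/C(=O)N(CN2CCN(c3ccnc4cc(Cl)ccc34)CC2)c2ccccc21` — in an ADME assay on MCF-10A cells (Homo sapiens) for cytotoxicity, read by sulforhodamine B assay, with a stated time of 48 h (on this read-out lower numbers stand for stronger inhibition of growth and higher numbers for weaker inhibition of growth), compound 1 gives 27700 nM
- compound 2 `NC(=S)N/N=C1/C(=O)N(CN2CCN(c3ccnc4cc(C(F)(F)F)ccc34)CC2)c2cccc(Cl)c21` — in this assay compound 2 gives 51700 nM
- compound 3 `NC(=S)N/N=C1/C(=O)N(CN2CCN(c3ccnc4cc(C(F)(F)F)ccc34)CC2)c2cc(Cl)ccc21` — in this assay compound 3 gives 38800 nM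

The three compounds share the same core and differ only in the substituents on the two aromatic parts. Compound 3 sits between the other two numbers, and its gaps to compound 2 and to compound 1 both lie within the scatter of repeated measurements, so the three values are indistinguishable on this read-out; no ranking among them is supported.

The next compound, compound 4 `NC(=S)N/N=C1/C(=O)N(CN2CCN(c3ccnc4cc(C(F)(F)F)ccc34)CC2)c2ccccc21`, follows from compound 3 by hydrogen in place of chloro on an aromatic carbon. The measured set contains no single-point comparison between two compounds. The effect of this change is therefore not known from a step here. Since the values of compounds 1, 2 and 3 all lie within the scatter of one another, the expectation is that the step of a 1.1-fold lower number from compound 3 to compound 4 (0.03 log units; within the scatter) will not exceed the scatter in either direction. Compound 4 is therefore estimated at 36000 nM in this assay, with a range from 16000 nM to 80000 nM.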

Compound 4, concentration for 50% growth inhibition: 22600 nM
The estimate for compound 4 lay 1.6-fold (0.20 log units) above the measured number, within the range that was stated.
By their numbers in this assay, from the lowest: compounds 4, 1, 3 and 2 (each within the scatter of the next, the first and the last beyond it).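

Hydrogen in place of chloro on an aromatic carbon can now be read twice in this assay as a 1.7-fold lower number from compound 3 to compound 4 (0.23 log units; within the scatter) and as a 2.3-fold lower number from compound 2 to compound 4 (0.36 log units; beyond the scatter) on the shared core. At the carbon described as meta to a fused ring and para to a fused ring, chloro and hydrogen therefore cannot be told apart on this read-out, whereas removing the chloro of compound 2, which stands on a different aromatic carbon, gives a modest step that is the only one here beyond the scatter. On the other aromatic part, trifluoromethyl in place of chloro gives a 1.2-fold lower number from compound 1 to compound 4 (0.09 log units; within the scatter) and so also leaves the number unresolved in this comparison.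

Going by these compounds, whether an amine or a carboxylic acid on the aromatic carbon carrying the chloro of compound 3 would move the number beyond the scatter remains open, as does the effect of either group in place of trifluoromethyl. No measurement at hand bears on why these steps have the sizes they do.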